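The compounds below may be only part of what the source reports. "The series", "measured", "known", "first", "only" and "open" are said of these compounds alone.

In a physicochemical assay for solubility, using the shake flask method, in simulated intestinal fluid, measured as kinetic solubility, with a stated time of 2 h, at 25 degrees C, at pH 6.5 (on this read-out higher numbers stand for higher solubility and lower numbers for lower solubility), compound 3 `COc1cccc(CN2C(=O)c3c(C)nc(-c4nc(C)no4)c(N)c3C2=O)c1` gives < 5000 nM, a limit and not a number. Compound 1 `Cc1noc(-c2nc(C)c3c(c2N)C(=O)N(Cc2ccccc2)C3=O)n1` gives < 5000 nM, also a limit. Compound 2 `Cc1noc(-c2nc(C)c3c(c2N)C(=O)N(CC2CCNCC2)C3=O)n1` reaches 160000 nM. Compound 4 `Cc1noc(-c2nc(C)c3c(c2N)C(=O)N(Cc2ccc(OC(F)F)cc2)C3=O)n1` carries 4-(difluoromethoxy)phenyl in place of 3-methoxyphenyl on a saturated chain carbon bound to an amide-type nitrogen in a ring. The nearest measured change on the phenyl ring is a step that the two limits leave unreadable from compound 1 to compound 3. The readable steps, an at least 32-fold higher number from compound 1 to compound 2 (1.50 log units; beyond the scatter) and an at least 32-fold lower number from compound 2 to compound 3 (1.50 log units; beyond the scatter), are both large, but each exchanges piperidin-4-yl, which plays no part in this change. No step beyond the scatter is therefore expected in this assay. The expected outcome is a step that the limit leaves unreadable from compound 3 to compound 4. Compound 4 is estimated at 3000 nM, within an expected range from 1000 nM to 7000 nM.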

Compound 4, solubility: < 5000 nM
Compound 4 gave a limit, no number; the forecaster's own chance of this, stated with the estimate: 85%; the middle value does not contradict the limit.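

Putting 4-(difluoromethoxy)phenyl in place of piperidin-4-yl on the saturated chain carbon gives an at least 32-fold lower number from compound 2 to compound 4 (1.50 log units; beyond the scatter) in this assay. The steps from compound 1 and from compound 3 to compound 4 join two limits and cannot be read. A fluorine-bearing group at this place thus joins the phenyl of compound 1 and the 3-methoxyphenyl of compound 3, with only compound 2 standing clear of the limit: the limit of < 5000 nM in this assay, at which 3 of the 4 values shown sit.

Going by these compounds, how compound 1, compound 3 and compound 4 rank under that limit stays open. Also open, on these data alone, is whether an amine or a carboxylic acid on the phenyl ring would give a readable number.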